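A Morpholine Amide Replaces the Pyrrolidine of Compound 1

The source may report more compounds than this note shows. Statements on the series, on what has been measured and on what is new or still open speak of the compounds shown alone.

The measure here is a functional assay on CHO cells for antagonist activity at sphingosine 1-phosphate receptor 2 (Homo sapiens), read by GTPgammaS binding; on this read-out higher numbers stand for weaker inhibition and lower numbers for stronger inhibition. Three compounds have been run so far. Compound 1, with structure `O=C(Cc1nn(C2CCNC2)c(=O)c2ccccc12)Nc1ccc(OC(F)(F)F)c(Cl)c1`, gives 42 nM in this assay. Compound 2, with structure `CCOc1cc2[nH]c(Cc3nn(CC(=O)N4CCOCC4)c(=O)c4ccccc34)nc2cc1Cl`, gives 22 nM, and compound 3, with structure `O=C(O)C1(c2nn(Cc3cn4cc(OCC5CC5)c(Cl)cc4n3)c3ccccc3c2=O)CC1`, gives 82 nM. Compound 1 stands second highest of the three; its gap to compound 2 and its gap to compound 3 both lie within the usual scatter, so the three cannot be ranked against each other.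

Compound 4, with structure `O=C(Cc1nn(CC(=O)N2CCOCC2)c(=O)c2ccccc12)Nc1ccc(OC(F)(F)F)c(Cl)c1`, has not yet been measured. It differs from compound 1 in one place: ((morpholin-4-yl)carbonyl)methyl in place of pyrrolidin-3-yl on an aromatic nitrogen. Among the compounds with values here, the same ((morpholin-4-yl)carbonyl)methyl group sits on the aromatic nitrogen of compound 2, which gives 22 nM in this assay, though compound 2 carries a different other half, so no direct step is available. Compound 4 is therefore expected to land close to compound 1, with a step of a 1.4-fold lower number from compound 1 to compound 4 (0.15 log units; within the scatter) that is not expected to exceed the scatter. The estimate for compound 4 is 30 nM, within a range from 12 nM to 90 nM.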

Compound 4, half-maximal inhibitory concentration: 103 nM
Compound 4: the middle estimate sits 3.4-fold (0.54 log units) below what was measured; measured number outside the range, above it.
By their numbers in this assay, from the lowest: compounds 2, 1, 3 and 4 (each within the scatter of the next, the first and the last beyond it).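

Swapping pyrrolidin-3-yl for ((morpholin-4-yl)carbonyl)methyl on this aromatic nitrogen gives a 2.5-fold higher number from compound 1 to compound 4 (0.39 log units; beyond the scatter) in this assay. Within the data shown here, the step is modest, but it is the first change at this position that stands beyond the scatter, so with the rest of compound 1 held fixed, the group here does affect the read-out. No measurement shown explains why the number rises.

Among these compounds, the single step swaps a ring carrying a hydrogen-bond donor for a larger group with a carbonyl and no donor, so it leaves open which of these differences matters. Going by these compounds, a simple amine chain such as 2-aminoethyl on the same aromatic nitrogen would help separate them, and whether the step holds with a different other half also remains open.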